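This account rests on a few compounds, and the source may have more. Where it says the series, first, only, none or still open, it means among the compounds named here.

Compound 1, with the structure `Cc1c(-c2ccc(Cc3ccc(C(C)(O)C(F)(F)F)cc3)cc2)[nH]c2cccc(F)c2c1=O`, is the starting point here. In an ADME assay on Huh7.5.1 cells (Homo sapiens) for cytotoxicity, read by WST assay, with a stated time of 48 h (on this read-out lower numbers stand for higher toxicity in this test and higher numbers for lower toxicity in this test), compound 1 gives > 2500 nM, which is a limit of the assay rather than a number, so where compound 1 stands can only be told as a limit. Among the compounds with values here, its one measured neighbour is compound 2, with the structure `Cc1c(-c2ccc(Cc3ccc(S(F)(F)(F)(F)F)cc3)cc2)[nH]c2cccc(F)c2c1=O`. In this assay compound 2 gives > 5000 nM, again a limit and not a number. Within the data shown here, the only measured step, a step that the two limits leave unreadable from compound 1 to compound 2, therefore has no readable size.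

The compound still to be measured is compound 3, with the structure `COc1ccc(Cc2ccc(-c3[nH]c4cccc(F)c4c(=O)c3C)cc2)cc1`. It differs from compound 1 by methoxy in place of 1-hydroxy-1-(trifluoromethyl)ethyl on an aromatic carbon. Among the measured compounds shown here, no measured step bears on this change. The evidence on hand consists of the limit of > 2500 nM in this assay, at which 1 of the 2 values shown sits, for compound 1, and of the limit of > 5000 nM in this assay, at which 1 of the 2 values shown sits, for compound 2, so no direction or size of step can be drawn from the numbers. For compound 3 the expected step is therefore a step that the limit leaves unreadable from compound 1 to compound 3, meaning no change beyond the scatter is expected. Compound 3 is estimated to give 8000 nM in this assay, within a range from 2500 nM to 30000 nM, with a good chance that only a limit is reported.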

Compound 3, half-maximal cytotoxic concentration: > 10000 nM
Compound 3 gave a limit, no number (the forecaster's own chance of this, stated with the estimate: 70%); middle value at least 1.2-fold (0.09 log units) away from the limit.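

Compound 3, like compound 1 and compound 2, gives only a limit in this assay and not a number, so none of the steps among these three compounds can be read. The compounds shown leave open the concentration at which any of them becomes toxic to these cells, and whether changing the group on the aromatic carbon shifts it.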